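Spirooxindole series: antiproliferative readout on normal liver cells

This account rests on a few compounds, and the source may have more. Where it says the series, first, only, none or still open, it means among the compounds named here.

Measured so far:
compound 1, `Cc1ccc(C)c(-n2nncc2CN2C(=O)C3(C(C#N)=C(N)Oc4c3c3nc5ccccc5nc3c3ccccc43)c3ccccc32)c1`: > 50000 nM
compound 2, `N#CC1=C(N)Oc2c(N)cc3nc4ccccc4nc3c2C12C(=O)N(Cc1cnnn1-c1cccc(C(F)(F)F)c1)c1ccccc12`: 38100 nM

For the measured compounds named here, in an ADME assay on L02 cells (Homo sapiens) for antiproliferative activity, read by MTT assay, with a stated time of 48 h (a lower number here means a stronger inhibitor, a higher number a weaker inhibitor), compound 2 gives 38100 nM, and this is the only actual number in the set. Compound 1 returns only a limit of the assay, > 50000 nM, so it offers no number to compare against; the relevant line is the limit of > 50000 nM in this assay, at which 1 of the 2 values shown sits. Going by the values given here, since the two compounds differ in more than one place, no step between them is defined, and the pair shows only that one value is a weak number and the other a limit.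

Compound 3, `N#CC1=C(N)Oc2c(N)cc3nc4ccccc4nc3c2C12C(=O)N(Cc1cnnn1-c1ccc(F)c(Cl)c1)c1ccccc12`, is the untested member. It differs from compound 2 by 3-chloro-4-fluorophenyl in place of 3-(trifluoromethyl)phenyl on an aromatic nitrogen, on the aromatic nitrogen of the five-membered aromatic ring with three nitrogens. Nothing measured in this set isolates such a change, so the expectation rests on compound 2 alone. The step of a 1.0-fold higher number from compound 2 to compound 3 (0.02 log units; within the scatter) is expected to stay within the usual scatter, in no particular direction. Compound 3 is therefore estimated at 40000 nM in this assay, with a range from 15000 nM to 100000 nM, and a fair chance that the assay again reports only a limit.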

Compound 3, half-maximal inhibitory concentration: > 50000 nM
Compound 3 was reported as a limit (the forecaster's own chance of this, stated with the estimate: 40%); middle value at least 1.2-fold (0.09 log units) from the limit.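

In this assay, for the compounds shown here, placing 3-chloro-4-fluorophenyl instead of 3-(trifluoromethyl)phenyl on the aromatic nitrogen of the five-membered aromatic ring with 3 nitrogen gives the first step that can be read at this position: an at least 1.3-fold higher number from compound 2 to compound 3 (0.11 log units; that floor lies within the scatter). Compound 3 gives > 50000 nM, which is a limit of the assay and not a number. The step therefore sets only a floor within the scatter, so this exchange of one halogen-bearing phenyl group for another shows no separation between the two compounds, and the limit now accounts for most of the series as shown: the limit of > 50000 nM in this assay, at which 2 of the 3 values shown sit.

As far as these compounds go, the true size of the step stays open, as the value of compound 3 has no upper end. Also open, from the compounds shown here alone, is whether a different substituent on this phenyl ring, such as a dimethylamino group or a carboxylic acid in place of the halogens, would give a number clearly apart from those of compound 2 and compound 3 in this assay.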